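The source may hold more compounds than are shown below. What is called first, only, known or untested is meant among the compounds shown, and "the series" means these compounds.

Of the compounds shown here, three built on one shared core have been tested in an ADME assay on BV-2 cells (Mus musculus) for cytotoxicity, with a stated time of 24 h, tested at 10 uM; on this read-out higher numbers stand for a weaker effect at the one concentration tested and lower numbers for a stronger effect. Compound 1 `COc1ccccc1S(=O)(=O)/C=C/c1ccccn1` gives 100%, compound 2 `COc1cccc(S(=O)(=O)/C=C/c2cccc(Cl)n2)c1` gives 100%, and compound 3 `COc1ccccc1S(=O)(=O)/C=C/c1cccnc1` gives 100%, so compound 3 stands level with both of the others. Among the measured compounds shown here, the single one-place step measured so far, no change at the digits printed from compound 1 to compound 3 (within the scatter), left the read-out where it was. Compound 4 `COc1ccccc1S(=O)(=O)/C=C/c1cccnc1OC` differs from compound 3 by methoxy in place of hydrogen on an aromatic carbon. For the measured compounds named here, no measured step places a methoxy on this ring, so the only guide is that the one step seen so far stayed within the scatter. The expected step is therefore none beyond the scatter, no change at the digits printed from compound 3 to compound 4 (within the scatter). In this assay compound 4 is estimated at 100%, within a range from 90% to 105%.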

Compound 4, a percentage reported as activity, at one concentration (the size of the read-out at that concentration, not a potency): 100%
For compound 4 middle estimate and measured number coincide at the digits printed, within the range that was stated.
By their numbers in this assay, from the lowest: compounds 1, 2, 3 and 4 (each within the scatter of the next).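

In this assay, methoxy in place of hydrogen on an aromatic carbon, next to the ring nitrogen and ortho to a large group, gives no change at the digits printed from compound 3 to compound 4 (within the scatter). Among the compounds shown here, this is the first one-place step that adds heavy atoms rather than shifting the ring nitrogen, and this crowded place accepts them without a change beyond the scatter. Nothing available explains this result.

On these data alone, whether an amine, a carboxylic acid or a longer chain at this place would behave the same in this assay remains open. So does whether any change to the shared core can lower the read-out.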